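The source may hold more compounds than are shown below. What is called first, only, known or untested is meant among the compounds shown, and "the series" means these compounds.

Measured in a functional assay on A 172 cells (Homo sapiens) for cytotoxicity, read by colorimetric assay and MTT assay; on this read-out higher numbers stand for weaker inhibition and lower numbers for stronger inhibition:
- compound 1 `COc1cc(OC)c2cc(-c3ccccc3)c(O)nc2c1`: 10000 nM
- compound 2 `COc1ccc(-c2cc3c(OC)cc(OC)cc3n(CC#N)c2=O)cc1`: 10000 nM

Level with compound 1, compound 2 stands at 10000 nM, with no difference beyond the scatter. Compound 3 `COc1ccc(-c2cc3c(OC)cc(OC)cc3n(CCC(=O)OCc3ccccc3)c2=O)cc1` carries (benzyloxycarbonyl)methyl in place of cyano on a saturated chain carbon bound to an aromatic nitrogen. Going by the values given here, no measured step gives a scale for this change. In this assay, no step beyond the scatter is expected, with any drift toward stronger inhibition. The estimated change, a 1.3-fold lower number from compound 2 to compound 3 (0.10 log units; within the scatter), is small. For compound 3 the expected value is 8000 nM, with an estimated range from 3000 nM to 20000 nM.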

Compound 3, half-maximal inhibitory concentration: 10000 nM
For compound 3 the middle estimate is 1.3-fold (0.10 log units) below the measured one; measured number inside the range.
By their numbers in this assay, from the lowest: compounds 1, 2 and 3 (each within the scatter of the next).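

In this assay, (benzyloxycarbonyl)methyl in place of cyano on a saturated chain carbon bound to an aromatic nitrogen gives no change at the digits printed from compound 2 to compound 3 (within the scatter). Going by these compounds alone, this is the first step that can be read at this position, and it shows that the read-out holds when the larger group, with its added six-membered aromatic ring, enters. No evidence on hand bears on this result.

From the compounds shown here alone, whether a carboxylic acid or an amine in the same place would move the number away from that of compound 2 remains open.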